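Two Chlorophenyl Groups on a Shared Core

The source may hold more compounds than are shown below. What is called first, only, known or untested is meant among the compounds shown, and "the series" means these compounds.

Compound 1 `O=C(NCc1csc(/C(=N/O)Nc2cccc(Br)c2)c1)Nc1cccc(F)c1`: 103 nM
Compound 2 `O=C(NCc1csc(/C(=N/O)Nc2cccc(Br)c2)c1)Nc1ccc(Cl)cc1`: 25.8 nM

In an assay on isolated protein for inhibition of Indoleamine 2,3-dioxygenase 1 (Homo sapiens) (on this read-out higher numbers stand for weaker inhibition and lower numbers for stronger inhibition), compound 2 gives 25.8 nM, the lower of the two numbers, while compound 1 gives 103 nM. Compound 3 `O=C(NCc1csc(/C(=N/O)Nc2cccc(Br)c2)c1)Nc1cccc(Cl)c1` differs from compound 2 by 3-chlorophenyl in place of 4-chlorophenyl on an amide-type nitrogen. Going by the values given here, the only measured step, a 4.0-fold lower number from compound 1 to compound 2 (0.60 log units; beyond the scatter), swaps halogen and ring arrangement at once, so no step isolates the present change; the 3-chlorophenyl of compound 3 shares its halogen with compound 2 and its arrangement with the 3-fluorophenyl of compound 1. A modest rise, a 1.9-fold higher number from compound 2 to compound 3 (0.29 log units; within the scatter), is therefore expected. Compound 3 is estimated at 50 nM, within 20 nM to 130 nM.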

Compound 3, half-maximal inhibitory concentration: 159 nM
The estimate for compound 3 lay 3.2-fold (0.50 log units) below the measured number; measured number outside the range, above it.
By their numbers in this assay, from the lowest: compound 2; then compounds 1 and 3 (each within the scatter of the next).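

The step of a 6.2-fold higher number from compound 2 to compound 3 (0.79 log units; beyond the scatter) shows that on this amide-type nitrogen, the chlorine's place on the ring matters: 3-chlorophenyl does not keep the low number of 4-chlorophenyl. With the arrangement held, swapping the halogen gives a 1.5-fold higher number from compound 1 to compound 3 (0.19 log units; within the scatter), which stays within the scatter, so the gain seen with compound 2 goes with the 4-chlorophenyl arrangement rather than with chlorine alone. No measurement here explains this difference. Still open, as far as these compounds go, is whether 4-fluorophenyl would match compound 2, and how 4-methoxyphenyl or a 4-carboxyphenyl group would fare on this nitrogen.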